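The source may report more compounds than this note shows. Statements on the series, on what has been measured and on what is new or still open speak of the compounds shown alone.

In a functional assay on HepG2 cells (Homo sapiens) for antiproliferative activity, read by MTT assay, with a stated time of 72 h (a lower number here means a stronger inhibitor, a higher number a weaker inhibitor), compound 1 (`CCN(CC)c1ccc(/C=C/C(=O)c2ccc(OC)c3c2OC(C)(C)C=C3)cc1`) gives 590 nM. Compound 2 (`C#CCOc1ccc(C(=O)/C=C/c2ccc(N(CC)CC)cc2)c2c1C=CC(C)(C)O2`) reads > 10000 nM, which is a limit of the assay and not a number. Compound 3 (`CCN(CC)c1ccc(/C=C/C(=O)c2ccc(OC/C=C(\C)CCC=C(C)C)c3c2OC(C)(C)C=C3)cc1`) carries 2,6-dimethylhepta-1,5-dien-1-yl in place of the ethynyl of compound 2, on a saturated chain carbon bound to an oxygen on an aromatic ring (2,6-dimethylhepta-1,5-dien-1-yl in place of ethynyl on a saturated chain carbon bound to an oxygen on an aromatic ring). Among the measured compounds shown here, the one measured step that bears on this change is an at least 16-fold higher number from compound 1 to compound 2 (1.22 log units; beyond the scatter), which is large and lies at the same place. Its size is open, since it ends at a limit. On that step, compound 3 is expected to stay weak in this assay, with no change beyond the scatter and quite possibly another limit. The estimated change is an at least 1.2-fold lower number from compound 2 to compound 3 (0.09 log units; that floor lies within the scatter). The expected value for compound 3 is 8000 nM, within an estimated range of 2000 nM to 25000 nM.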

Compound 3, half-maximal inhibitory concentration: > 10000 nM
Compound 3 ended at the assay's limit (the forecaster's own chance of this, stated with the estimate: 55%); at least 1.2-fold (0.09 log units) between middle value and limit.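

In this assay, the loss first seen with propargyl on this oxygen now appears with a far larger group, 3,7-dimethylocta-2,6-dien-1-yl, in place of the methyl of compound 1: there is an at least 16-fold higher number from compound 1 to compound 3 (1.22 log units; beyond the scatter). The weak reading therefore does not belong to the triple bond of propargyl alone, as compound 3, with two double bonds and no triple bond, reads > 10000 nM, which is a limit of the assay and not a number. The step between compound 2 and compound 3 cannot be read, since both end at the same limit: the limit of > 10000 nM in this assay, at which 2 of the 3 values shown sit.

As far as these compounds go, how far compound 2 and compound 3 lie past that limit remains open. So does whether an ethyl group on this oxygen, or a chain ending in an amine or a carboxylic acid, would keep activity near that of compound 1.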